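Thiourea series: furan-2-yl in place of tert-butylphenyl

The source may report more compounds than this note shows. Statements on the series, on what has been measured and on what is new or still open speak of the compounds shown alone.

Working notes on three aroyl thioureas sharing one core, measured in an ADME assay on Huh-7 cells (Homo sapiens) for cytotoxicity; on this read-out higher numbers stand for lower toxicity in this test and lower numbers for higher toxicity in this test. Compound 1 `O=C(NC(=S)N1CCc2c(OCCCCCOc3ccc(Cl)cc3)cccc21)c1ccc([N+](=O)[O-])cc1` gives 13600 nM. Compound 2 `N#Cc1cccc(C(=O)NC(=S)N2CCc3c(OCCCCCOc4ccc(Cl)cc4)cccc32)c1` gives 9750 nM, with the step of a 1.4-fold lower number from compound 1 to compound 2 (0.14 log units; within the scatter). Compound 3 `CC(C)(C)c1ccc(C(=O)NC(=S)N2CCc3c(OCCCCCOc4ccc(Cl)cc4)cccc32)cc1` returns only a limit of the assay, > 50000 nM, not a number; this is the limit of > 50000 nM in this assay, at which 1 of the 3 values shown sits. The steps of an at least 3.6-fold higher number from compound 1 to compound 3 (0.56 log units; beyond the scatter) and an at least 5.1-fold higher number from compound 2 to compound 3 (0.70 log units; beyond the scatter) both run upward toward compound 3, so compound 3 stands as the highest reading of the three, as far as a limit allows.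

Compound 4 `O=C(NC(=S)N1CCc2c(OCCCCCOc3ccc(Cl)cc3)cccc21)c1ccco1` differs from compound 3 by furan-2-yl in place of 4-(tert-butyl)phenyl on a carbonyl carbon. For the measured compounds named here, no measured step involves furan-2-yl; the two steps on the aryl group at the carbonyl carbon show only that this group moves the number. A downward step in this assay is therefore expected, an at least 2.5-fold lower number from compound 3 to compound 4 (0.39 log units; beyond the scatter), of uncertain size. Compound 4 is estimated at 20000 nM, expected between 8000 nM and 60000 nM.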

Compound 4, half-maximal cytotoxic concentration: 4620 nM
For compound 4 the middle estimate is 4.3-fold (0.64 log units) above the measured one; measured number below the stated range.
By their numbers in this assay, from the lowest: compound 4; then compounds 2 and 1 (each within the scatter of the next). At a limit, above all of these: compound 3.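

In this assay furan-2-yl on a carbonyl carbon gives the lowest number of the four, a step beyond the scatter against 3-cyanophenyl (a 2.1-fold lower number from compound 2 to compound 4 (0.32 log units; beyond the scatter)) and against 4-nitrophenyl (a 2.9-fold lower number from compound 1 to compound 4 (0.47 log units; beyond the scatter)). Against 4-(tert-butyl)phenyl the step is large (an at least 10-fold lower number from compound 3 to compound 4 (1.03 log units; beyond the scatter)). Its size is only a minimum, as compound 3 sits at a limit and not a number: (the limit of > 50000 nM in this assay, at which 1 of the 4 values shown sits). Open, on these data alone, is whether the lower number follows the fewer heavy atoms or the ring oxygen of furan-2-yl, and how unsubstituted phenyl or thiophen-2-yl would read on this carbonyl carbon.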